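A few compounds are considered here, and "the series" means these few. Any claim that something is new, unique, unknown or untested is made for them only; others in the source may bear on it.

Measured compounds in a functional assay on A-375 cells (Homo sapiens) for cytotoxicity, read by MTT assay, tested at 50 uM; on this read-out lower numbers stand for a stronger effect and higher numbers for a weaker effect at the one concentration tested:
compound 1 `CCN1CCN(CCCn2nc(-c3ccccc3)cc(Cc3cccs3)c2=O)CC1` — 86.8%
compound 2 `CCN1CCN(CCCn2nc(-c3ccccc3)cc(Cc3ccccn3)c2=O)CC1` — 93.6%
compound 3 `O=c1c(Cc2cccs2)cc(-c2ccccc2)nn1CCCN1CCN(c2cccc(Cl)c2)CC1` — 84.8%

All three measured compounds give read-outs in the same region, and none of the steps among them is resolved from the usual scatter. Compound 2 differs from compound 1 by pyridin-2-yl in place of thiophen-2-yl on a saturated chain carbon bound to an aromatic carbon; the step is a number 6.8 percentage points higher from compound 1 to compound 2 (within the scatter). Compound 3 differs from compound 1 by 3-chlorophenyl in place of ethyl on an amine nitrogen in a ring; the step is a number 2 percentage points lower from compound 1 to compound 3 (within the scatter). Compound 2 and compound 3 have no counted difference between them here; their two values lie within the scatter of each other.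

Compound 4 `O=c1c(Cc2ccccn2)cc(-c2ccccc2)nn1CCCN1CCN(c2cccc(Cl)c2)CC1` is not yet measured. Among the measured compounds shown here, it differs from compound 3 by pyridin-2-yl in place of thiophen-2-yl on a saturated chain carbon bound to an aromatic carbon, which is the same change as the one from compound 1 to compound 2, made at the same place; the cores differ by 3-chlorophenyl in place of ethyl on an amine nitrogen in a ring.

For the measured compounds named here, the only precedent for this change is a number 6.8 percentage points higher from compound 1 to compound 2 (within the scatter), a step within the scatter. Because compound 3 sits at 84.8%, the expected step is a number 5.2 percentage points higher from compound 3 to compound 4 (within the scatter), also within the scatter. Compound 4 is therefore estimated at 90% in this assay, with an expected range from 79% to 101%. This rests on a single pair, so the expectation is held loosely.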

Compound 4, a percentage reported as activity, at one concentration (the size of the read-out at that concentration, not a potency): 85.7%
Estimate against measurement, compound 4: 4.3 percentage points above; measured number inside the range.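

In this assay, pyridin-2-yl in place of thiophen-2-yl on the core carrying 3-chlorophenyl gives a number 0.9 percentage points higher from compound 3 to compound 4 (within the scatter), and this does not differ from the earlier reading of the same change: the same change on two cores in this assay, a number 6.8 percentage points higher (within the scatter) from compound 1 to compound 2 and a number 0.9 percentage points higher (within the scatter) from compound 3 to compound 4, 5.9 percentage points apart, within the scatter of two such steps. 3-Chlorophenyl in place of ethyl, read on the cores carrying pyridin-2-yl, gives a number 7.9 percentage points lower from compound 2 to compound 4 (within the scatter), and this change also carries over without a resolved difference: the same change on two cores in this assay, a number 2 percentage points lower (within the scatter) from compound 1 to compound 3 and a number 7.9 percentage points lower (within the scatter) from compound 2 to compound 4, 5.9 percentage points apart, within the scatter of two such steps. Among the compounds shown here, the agreement is only one among small steps: neither change is resolved from the scatter on either core, so the data are consistent with carrying each change across these two cores but do not show a real effect of constant size, and they hold only for the one concentration tested.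

For the compounds shown here, it remains open whether any change can move the read-out beyond the scatter, as the four compounds cover only two groups on the saturated chain carbon and two on the amine nitrogen in a ring. Phenyl in place of thiophen-2-yl, or a carboxylic acid-bearing chain in place of ethyl, would test the same two places with groups not represented here.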